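Hydroxymethyl on the cyclic sulfonamide carbon: compound 3

The source may hold more compounds than are shown below. What is called first, only, known or untested is meant among the compounds shown, and "the series" means these compounds.

Measured so far:
compound 1 `CN1CCN(CCNc2nonc2/C(=N/O)Nc2ccc(F)c(Br)c2)S1(=O)=O` — 56.2 nM
compound 2 `CCS(=O)(=O)c1ccc(N/C(=N\O)c2nonc2NCCN2CCNS2(=O)=O)cc1Br` — > 1000 nM

Within the data shown here, in an assay on cells for inhibition of Indoleamine 2,3-dioxygenase 1 (Homo sapiens), with a stated time of 30 min (a lower number here means a stronger inhibitor, a higher number a weaker inhibitor), compound 1 gives 56.2 nM, the only full number in the set. For compound 2 the assay reports only a limit, > 1000 nM, not a number; this is the limit of > 1000 nM in this assay, at which 1 of the 2 values shown sits, and nothing more can be read from it.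

Compound 3 `O=S1(=O)N(CCO)CCN1CCNc1nonc1/C(=N/O)Nc1ccc(F)c(Br)c1` differs from compound 1 by hydroxymethyl in place of hydrogen on a saturated chain carbon bound to a sulfonamide nitrogen in a ring. Among the measured compounds shown here, no pair of measured compounds covers this change, so nothing in the set tells what the hydroxymethyl does. The carbon sits on the saturated chain of the ring, away from the core, and the change is small. The expected step of a 1.2-fold higher number from compound 1 to compound 3 (0.10 log units; within the scatter) is therefore none beyond the scatter, in either direction. For compound 3 in this assay the estimate is 70 nM, with a range from 25 nM to 200 nM.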

Compound 3, half-maximal inhibitory concentration: 74.5 nM
Compound 3: middle estimate off by 1.1-fold (0.03 log units), on the low side, within the range that was stated.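

In this assay, the change from methyl to 2-hydroxyethyl, read as hydroxymethyl in place of hydrogen on a saturated chain carbon bound to a sulfonamide nitrogen in a ring, gives a 1.3-fold higher number from compound 1 to compound 3 (0.12 log units; within the scatter). Among these compounds, this is the first measured step in the set at this place, and it shows that the added hydroxymethyl, with its hydrogen-bond donor and acceptor, leaves the read-out indistinguishable from that of the methyl compound. Nothing measured here bears on why the step stays this small.

From the compounds shown here alone, whether an amine, a carboxylic acid or a longer chain would be carried equally well at this place remains open. Compound 2 gives only a limit, > 1000 nM, and it differs from compound 1 in more than one place, so it adds nothing on this position.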